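The compounds below may be only part of what the source reports. "The series", "measured", "known", "first", "only" and "open" are said of these compounds alone.

Measured compounds in an assay on membranes from HEK293 cells for displacement of a labelled ligand from adenosine receptor A2b (Homo sapiens), read by scintillation counting, with a stated time of 30 min, tested at 1 uM; a lower number here means less inhibition, a higher number more inhibition at the concentration tested (going by the name of the read-out):
compound 1 `CC1=C(C(=O)SC(C)C)C(c2ccsc2)NC(=O)N1` gives 14%
compound 2 `CCC(C)OC(=O)C1=C(C)NC(=O)NC1c1cccs1` gives 7%

Both numbers sit at the low end of what this assay reports, and the two compounds lie within the usual scatter of each other, so on the numbers shown compound 2 cannot be set apart from compound 1 in either direction. Within the data shown here, compound 1 and compound 2 differ from each other in more than one place, and no single step between them has been worked out; their two values show only that neither reaches a marked level of inhibition at the concentration tested.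

The next compound, compound 3 `CCC(C)OC(=O)C1=C(C)NC(=O)NC1c1ccsc1`, follows from compound 2 by one change: thiophen-3-yl in place of thiophen-2-yl on a saturated ring carbon. The group that leaves and the group that enters have the same atoms, joined differently, on a saturated ring carbon of the shared core.

Among the measured compounds shown here, no step between measured compounds is available to size this change. With both measured numbers low and within scatter of each other, the expectation for the step in this assay is none beyond the scatter, in no particular direction. Compound 3 is thus expected at 10%, in the range 0% to 25%, a step from compound 2 estimated as a number 3 percentage points higher from compound 2 to compound 3 (within the scatter).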

Compound 3, a percentage reported as inhibition, at one concentration (the size of the read-out at that concentration, not a potency): 39%
For compound 3 the middle estimate is 29 percentage points below the measured one; the measured number lies above the stated range.
By their numbers in this assay, from the lowest: compounds 2 and 1 (each within the scatter of the next); then compound 3.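

In this assay, thiophen-3-yl in place of thiophen-2-yl on a saturated ring carbon of the shared core gives a number 32 percentage points higher from compound 2 to compound 3 (beyond the scatter), so the read-out at this position depends on how the thiophene is joined, even though the group that leaves and the group that enters have the same atoms. With thiophen-3-yl on that carbon in both compounds, sec-butoxy in place of isopropylsulfanyl on the carbonyl carbon gives a number 25 percentage points higher from compound 1 to compound 3 (beyond the scatter), which shows that the group on the carbonyl also shifts the read-out, by a modest step beside the large one at the ring carbon. Nothing at hand explains either step.

Among these compounds, still open is whether the thiophen-3-yl gain carries over to the isopropylsulfanyl series, since the only pair with this exchange has sec-butoxy on the carbonyl carbon. Also open, on these data alone, is how a phenyl or furan-3-yl on the saturated ring carbon, or an ethoxy or a longer chain on the carbonyl carbon, would read, and whether the inhibition seen at one concentration reflects a useful potency.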